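A Smaller Ester on the Weaker Compound 2

The compounds below may be only part of what the source reports. "The series", "measured", "known", "first", "only" and "open" are said of these compounds alone.

Compound 1 `CCOC(=O)c1sc2cc(OC)ccc2c1Nc1cc(OC)c(OC)c(OC)c1` and compound 2 `CCOC(=O)c1sc2ncccc2c1Nc1cc(OC)c(OC)c(OC)c1` carry the same ester and the same amine substituent but differ in their core. In a functional assay on Jurkat cells (Homo sapiens) for cytotoxicity, read by MTT assay, with a stated time of 72 h (a higher number here means a weaker inhibitor, a lower number a stronger inhibitor), compound 1 gives 3.3 nM, while compound 2 gives 8450 nM, the highest of the two numbers and a gap from compound 1 that lies far beyond the scatter. Compound 3 `COC(=O)c1sc2ncccc2c1Nc1cc(OC)c(OC)c(OC)c1` keeps the core of compound 2 and alters only the ester: hydrogen in place of methyl on a saturated chain carbon bound to an oxygen next to a carbonyl group. Within the data shown here, no step of this kind between measured compounds is available here, so the size of its effect is not documented. Since the ester is held in common by compound 1 and compound 2 and the change touches nothing else, the expected step of a 1.1-fold lower number from compound 2 to compound 3 (0.02 log units; within the scatter) is estimated to be small, without a clear direction and most likely within the scatter. Compound 3 is expected to give 8000 nM, with a range from 3000 nM to 25000 nM.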

Compound 3, half-maximal inhibitory concentration: 1110 nM
Compound 3: middle estimate off by 7.2-fold (0.86 log units), on the high side; the measured number lies below the stated range.
By their numbers in this assay, from the lowest: compound 1; then compound 3; then compound 2.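

Ethoxycarbonyl to methoxycarbonyl on the core of compound 2 is the first change in a single place that can be read here, and in this assay it gives a 7.6-fold lower number from compound 2 to compound 3 (0.88 log units; beyond the scatter). This shows that the ester is not a silent position on this core: hydrogen in place of methyl on a saturated chain carbon bound to an oxygen next to a carbonyl group moves the number beyond the scatter, though the step is modest. No measurement at hand accounts for this step.

The compounds shown leave open whether ethyl to methyl would give a step of similar size and the same direction on the core of compound 1. They also leave open how a carboxylic acid, a primary amide or a propyl ester would read at this place.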